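Swapping methoxy for tert-butyl on the benzoyl of compound 3

The source may hold more compounds than are shown below. What is called first, only, known or untested is meant among the compounds shown, and "the series" means these compounds.

Of the compounds shown here, three sharing one core have been measured in an ADME assay on Huh-7 cells (Homo sapiens) for cytotoxicity; on this read-out lower numbers stand for higher toxicity in this test and higher numbers for lower toxicity in this test. Compound 1 `O=C(NC(=S)N1CCc2c(OCCCCCOc3ccc(Cl)cc3)cccc21)c1cccc([N+](=O)[O-])c1` gives 12100 nM, compound 2 `O=C(NC(=S)N1CCc2c(OCCCCCOc3ccc(Cl)cc3)cccc21)c1ccc(C(F)(F)F)cc1` gives 32700 nM, and compound 3 `COc1ccc(C(=O)NC(=S)N2CCc3c(OCCCCCOc4ccc(Cl)cc4)cccc32)cc1` gives 34400 nM. Compound 3 thus stands at the highest of the three numbers, though its gap to compound 2 is within the scatter, while the difference to compound 1 is beyond it, as the steps of a 2.8-fold higher number from compound 1 to compound 3 (0.45 log units; beyond the scatter) and a 2.7-fold higher number from compound 1 to compound 2 (0.43 log units; beyond the scatter) show.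

Compound 4 `CC(C)(C)c1ccc(C(=O)NC(=S)N2CCc3c(OCCCCCOc4ccc(Cl)cc4)cccc32)cc1` differs from compound 3 in one place: tert-butyl in place of methoxy on an aromatic carbon. The step that bears most directly on this is a 1.1-fold higher number from compound 2 to compound 3 (0.02 log units; within the scatter), an exchange of the same kind on the same aromatic carbon that left the number essentially unchanged. The two larger steps both start from compound 1 and concern a different substituent and position, so they speak less to this change.

On that basis, no step beyond the scatter is expected for compound 4 in this assay, and its number is estimated at 30000 nM, within a range from 12000 nM to 75000 nM. The expected step from compound 3 is a 1.1-fold lower number from compound 3 to compound 4 (0.06 log units; within the scatter).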

Compound 4, half-maximal cytotoxic concentration: > 50000 nM
Compound 4: no number, only a limit (the forecaster's own chance of this, stated with the estimate: 15%); at least 1.6-fold (0.22 log units) between middle value and limit.
By their numbers in this assay, from the lowest: compound 1; then compounds 2 and 3 (each within the scatter of the next). At a limit, above all of these: compound 4.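

Compound 4 gives no number in this assay, only a limit: the limit of > 50000 nM in this assay, at which 1 of the 4 values shown sits. Against the two closest compounds only floors can be stated, an at least 1.4-fold higher number from compound 3 to compound 4 (0.16 log units; that floor lies within the scatter) and an at least 1.5-fold higher number from compound 2 to compound 4 (0.18 log units; that floor lies within the scatter), so tert-butyl on this aromatic carbon, para to a large group, is not shown to differ from methoxy or trifluoromethyl, but it does extend the groups here that leave the read-out no lower than theirs to one of 4 carbons with no hydrogen-bond acceptor. Among the compounds shown here, the one step that clears the scatter is an at least 4.1-fold higher number from compound 1 to compound 4 (0.61 log units; beyond the scatter), which places compound 2, compound 3 and compound 4 all on the higher side of compound 1, the only compound of the four with its substituent not at this para carbon.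

Going by these compounds, how far compound 4 really lies past its limit stays unknown, and with it whether tert-butyl differs at all from methoxy or trifluoromethyl in this read-out. The compounds shown also leave open whether a nitro group on this same para carbon would give the lower number of compound 1, and how an amine or a carboxylic acid there would read.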